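The source may hold more compounds than are shown below. What is called first, only, known or untested is meant among the compounds shown, and "the series" means these compounds.

Working notes on the series. All four members share one core; they differ only in the group carried on an aromatic nitrogen of the five-membered aromatic ring with 3 nitrogen. Compound 1 `COc1ccc(/C=C\C(=O)O)c(OCc2cn(-c3ccccc3I)nn2)c1CC=C(C)C` is recorded as "not determined" (no result reported) in a functional assay on T47D cells (Homo sapiens) for cytotoxicity, read by MTT assay, with a stated time of 24 h (a lower number here means a stronger inhibitor, a higher number a weaker inhibitor), so no result is available for it. Compound 2 `COc1ccc(/C=C\C(=O)O)c(OCc2cn(-c3cccc([N+](=O)[O-])c3)nn2)c1CC=C(C)C` gives 15400 nM in this assay, and compound 3 `COc1ccc(/C=C\C(=O)O)c(OCc2cn(-c3ccc(CO)cc3)nn2)c1CC=C(C)C` gives 40000 nM in this assay. Among the measured compounds shown here, compound 3 thus stands at the highest number of the two measured, with compound 2 the nearest and the only measured step being a 2.6-fold higher number from compound 2 to compound 3 (0.41 log units; beyond the scatter), a modest one, beyond the scatter.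

Compound 4 `COc1ccc(/C=C\C(=O)O)c(OCc2cn(-c3cccc(C#N)c3)nn2)c1CC=C(C)C` is the next member: 3-cyanophenyl in place of 4-(hydroxymethyl)phenyl on an aromatic nitrogen. For the measured compounds named here, the single step that bears on this change is a 2.6-fold higher number from compound 2 to compound 3 (0.41 log units; beyond the scatter), which sets the scale of what an exchange of the group on that aromatic nitrogen has done so far. For compound 4 the step of a 1.8-fold lower number from compound 3 to compound 4 (0.26 log units; within the scatter) is expected to be modest and downward, landing between the two measured numbers. Compound 4 is estimated at 22000 nM in this assay, within a range from 9000 nM to 50000 nM.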

Compound 4, half-maximal inhibitory concentration: 19200 nM
For compound 4 the middle estimate is 1.1-fold (0.06 log units) above the measured one; low and high end bracket the measured number.
By their numbers in this assay, from the lowest: compounds 2 and 4 (each within the scatter of the next); then compound 3.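

The exchange of 4-(hydroxymethyl)phenyl for 3-cyanophenyl gives a 2.1-fold lower number from compound 3 to compound 4 (0.32 log units; beyond the scatter) and so shows a second modest step at this position, with the hydroxymethyl compound again at the higher number. Cyano in place of nitro on an aromatic carbon gives a 1.2-fold higher number from compound 2 to compound 4 (0.10 log units; within the scatter) in this assay and so adds a new kind of comparison, one that leaves compound 2 and compound 4 within the scatter of each other. No measured information is available to account for these steps.

Going by these compounds, whether the gap belongs to the hydroxymethyl group or to where it sits on the phenyl ring stays open, as the change from 4-(hydroxymethyl)phenyl to 3-cyanophenyl alters both at once. On these data alone, how an amine or a carboxylic acid would read in place of the nitrile also remains open.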